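Compound 4: does the benzothiazole change tolerance in Huh-7 cells?

The source may hold more compounds than are shown below. What is called first, only, known or untested is meant among the compounds shown, and "the series" means these compounds.

Values measured in a functional assay on Huh-7 cells (Homo sapiens) for cytotoxicity, read by MTT assay, with a stated time of 3 days; a higher number here means that more compound is tolerated, a lower number that less compound is tolerated:
- Compound 1 `OC[C@H]1O[C@@H](n2cnc3c(CSCc4ccccc4)ncnc32)[C@H](O)[C@@H]1O`: > 100000 nM, a limit
- Compound 2 `CSCc1ncnc2c1ncn2[C@@H]1O[C@H](CO)[C@@H](O)[C@H]1O`: > 100000 nM, a limit
- Compound 3 `OCCSCc1ncnc2c1ncn2[C@@H]1O[C@H](CO)[C@@H](O)[C@H]1O`: > 100000 nM, a limit

Compound 3 gives no number in this assay and stands only at the limit of > 100000 nM. The two other compounds offer no number to compare it with, as the series sits wholly at the limit of > 100000 nM in this assay, at which 3 of the 3 values shown sit.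

Compound 4 `OC[C@H]1O[C@@H](n2cnc3c(CSc4nc5ccccc5s4)ncnc32)[C@H](O)[C@@H]1O` keeps the shared core but carries 1,3-benzothiazol-2-yl in place of 2-hydroxyethyl on a sulfur. Among the measured compounds shown here, no measured step makes this same exchange. For the measured compounds named here, the closest is the one that swaps phenyl and hydroxymethyl, a step that the two limits leave unreadable from compound 1 to compound 3. Two others bear on it less directly, a step that the two limits leave unreadable from compound 1 to compound 2 and a step that the two limits leave unreadable from compound 2 to compound 3. None of the three has a readable size, so none can be carried over as a number. Going by the values given here, still, compound 1 is the only measured compound with an aromatic ring on its chain, and it too gives only a limit, > 100000 nM.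

The expected outcome is therefore no change beyond the scatter, with a real chance that compound 4 also returns only a limit. The expected step is a number no higher from compound 3 to compound 4 (the limit leaves the size open). For compound 4 the estimated value is 100000 nM, with an expected range from 30000 nM to 300000 nM.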

Compound 4, half-maximal cytotoxic concentration: > 100000 nM
Compound 4: only a limit was reported; the forecaster's own chance of this, stated with the estimate: 65%; the middle value sits exactly at the limit.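

In this assay compound 4 gives > 100000 nM as a limit and not a number. Its steps to compound 1, compound 2 and compound 3 therefore cannot be read, and the whole series rests on one value: the limit of > 100000 nM in this assay, at which 4 of the 4 values shown sit.

The four compounds leave open what concentration of any of them cells fail to tolerate, and whether the groups on the sulfur differ at all.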